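The source may hold more compounds than are shown below. What is called first, only, known or untested is meant among the compounds shown, and "the series" means these compounds.

Series notes. In an assay on cells for antagonist activity at transient receptor potential cation channel subfamily V member 1 (Homo sapiens), read by FLIPR and calcium flux, with a stated time of 6 min (a lower number here means a stronger inhibitor, a higher number a weaker inhibitor), compound 1 `CCCCSc1cc(C(C)(C)C)ccc1CNC(=O)C(C)c1ccc(NS(C)(=O)=O)c(F)c1` gives 6.7 nM, and compound 2 `CCCCCc1cc(C(C)(C)C)ccc1CNC(=O)C(C)c1ccc(NS(C)(=O)=O)c(F)c1` gives 2.8 nM. Among the compounds with values here, the one step inside the measured pair, a 2.4-fold lower number from compound 1 to compound 2 (0.38 log units; beyond the scatter), is the only change made so far at this position, and compound 2 stands at the lower of the two numbers, with compound 1 as its nearest neighbour.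

Compound 3 `CC(C(=O)NCc1ccc(C(C)(C)C)cc1C1CCCCC1)c1ccc(NS(C)(=O)=O)c(F)c1` keeps the core of compound 2 and differs only in the change (cyclohexyl in place of pentyl on an aromatic carbon). The measured step bears on it only loosely: a chain of carbon replaced another carbon-linked group and the number fell, while here a six-membered non-aromatic ring of carbon replaces a chain of similar heavy-atom count. Nothing measured separates ring from chain at this position, so the step from compound 2 to compound 3 is expected to be small in this assay, a 1.1-fold higher number from compound 2 to compound 3 (0.03 log units; within the scatter), likely within the scatter. For compound 3 the estimate is 3 nM, with a range from 1 nM to 9 nM.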

Compound 3, inhibition constant: 9.8 nM
Compound 3: middle estimate off by 3.3-fold (0.51 log units), on the low side, and the stated range ends below it.
By their numbers in this assay, from the lowest: compound 2; then compounds 1 and 3 (each within the scatter of the next).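

In this assay, ring and chain do not read alike at this position: cyclohexyl in place of pentyl on an aromatic carbon gives a 3.5-fold higher number from compound 2 to compound 3 (0.54 log units; beyond the scatter), so a close heavy-atom count does not by itself keep the number. Cyclohexyl in place of butylsulfanyl gives a 1.5-fold higher number from compound 1 to compound 3 (0.17 log units; within the scatter), which leaves compound 1 and compound 3 unseparated, with pentyl alone standing apart among the three groups. No available evidence bears on the reason for either step.

On these data alone, whether the lower number of compound 2 belongs to straight chains in general remains open, as a longer chain such as hexyl or a shorter one such as propyl would test that. As far as these compounds go, it is also open whether a cyclopentyl ring or a phenyl ring would read with cyclohexyl or with pentyl.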